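Adding a methyl to a well-tolerated cyclopentyl compound

The source may hold more compounds than are shown below. What is called first, only, known or untested is meant among the compounds shown, and "the series" means these compounds.

Compound 1 `CCC(C)Sc1nc(Cc2c(F)cccc2Cl)c(C)c(=O)[nH]1` gives > 73000 nM (a limit)
Compound 2 `CCCCSc1nc(Cc2c(F)cccc2Cl)c(C)c(=O)[nH]1` gives > 73000 nM (a limit)
Compound 3 `Cc1c(Cc2c(F)cccc2Cl)nc(SC2CCCC2)[nH]c1=O` gives > 71000 nM (a limit)

In an ADME assay on MT4 cells (Homo sapiens) for activation, read by MTT assay (a lower number here means that less compound is tolerated, a higher number that more compound is tolerated), compound 3 stands at > 71000 nM as a limit, not a number. Compound 4 `Cc1c(C(C)c2c(F)cccc2Cl)nc(SC2CCCC2)[nH]c1=O` differs from compound 3 in one place (methyl in place of hydrogen on a saturated chain carbon bound to two aromatic carbons) and nowhere else. The measured steps, a step that the two limits leave unreadable from compound 1 to compound 2 and a step that the two limits leave unreadable from compound 1 to compound 3 and a step that the two limits leave unreadable from compound 2 to compound 3, all concern the group on the sulfur, and none has a readable size. They therefore offer only weak guidance, and no step beyond the scatter is expected. The estimated move is an at least 1.0-fold lower number from compound 3 to compound 4 (0.03 log units; that floor lies within the scatter) and no larger. Compound 4 is expected at 65000 nM (estimated range 25000 nM to 80000 nM) in this assay and may well report only a limit.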

Compound 4, half-maximal cytotoxic concentration: > 15000 nM
Compound 4: a limit, no number (the forecaster's own chance of this, stated with the estimate: 65%); the middle value lies beyond the limit too.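

Among the compounds shown here, compound 3 and compound 4 each report only a limit, so no step between them can be read. Going by these compounds, whether the added methyl shifts how much compound is tolerated remains open, since neither compound has an actual number.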